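Naphthyl series: benzylamine swap toward compound 4

A few compounds are considered here, and "the series" means these few. Any claim that something is new, unique, unknown or untested is made for them only; others in the source may bear on it.

For the measured compounds named here, compound 3 `COc1ccc(F)cc1CNCCCNc1ccnc2cc(-c3cccc4ccccc34)ccc12` gives 32000 nM in a physicochemical assay for solubility, with a stated time of 18 h, at pH 7.4 (a higher number here means a more soluble compound, a lower number a less soluble compound), the highest of the three numbers so far; compound 1 `COc1cccc(CNCCCNc2ccnc3cc(Oc4ccc(F)cc4)ccc23)c1O` gives 14500 nM and compound 2 `COc1cccc(CNCCCNc2ccnc3cc(Cc4ccc(F)cc4)ccc23)c1O` gives 4200 nM. Going by the values given here, the only measured step, a 3.5-fold lower number from compound 1 to compound 2 (0.54 log units; beyond the scatter), alters a different part of the shared core and does not bear on the present change. Compound 4 `COc1cccc(CNCCCNc2ccnc3cc(-c4cccc5ccccc45)ccc23)c1O` differs from compound 3 by 2-hydroxy-3-methoxyphenyl in place of 5-fluoro-2-methoxyphenyl on a saturated chain carbon bound to an amine nitrogen. Among the compounds with values here, no measured pair isolates this swap, so its direction is open. The expectation is therefore a step within the scatter, a 1.3-fold lower number from compound 3 to compound 4 (0.11 log units; within the scatter), with the range kept wide. Compound 4 is expected to give 25000 nM in this assay, between 8000 nM and 70000 nM.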

Compound 4, solubility: 32000 nM
Beside the measured number, compound 4's estimate is 1.3-fold (0.11 log units) below it, within the range that was stated.
By their numbers in this assay, from the lowest: compound 2; then compound 1; then compounds 3 and 4 (each within the scatter of the next).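

With naphthalen-1-yl on the aromatic carbon, 2-hydroxy-3-methoxyphenyl in place of 5-fluoro-2-methoxyphenyl gives no change at the digits printed from compound 3 to compound 4 (within the scatter) in this assay, so this exchange on a saturated chain carbon bound to an amine nitrogen leaves the number unmoved. With 2-hydroxy-3-methoxybenzyl held constant, naphthalen-1-yl gives a 7.6-fold higher number from compound 2 to compound 4 (0.88 log units; beyond the scatter) against 4-fluorobenzyl and a 2.2-fold higher number from compound 1 to compound 4 (0.34 log units; beyond the scatter) against 4-fluorophenoxy on the aromatic carbon. Nothing at hand accounts for these steps. Still open, from the compounds shown here alone, is whether the swap reads the same with 4-fluorophenoxy or 4-fluorobenzyl on the aromatic carbon, and what a carboxylic acid in place of 2-hydroxy-3-methoxyphenyl would give.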